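Removing one methoxy group from compound 1

The compounds below may be only part of what the source reports. "The series", "measured", "known", "first", "only" and "open" are said of these compounds alone.

Compound 1 `COc1cc(-c2cc(/C=C/C(=O)c3ccc(N)cc3)[nH]n2)cc(OC)c1OC` carries an aminophenyl on the carbonyl carbon and three methoxy groups on the aryl attached to the shared core. In a functional assay on 786-0 cells (Homo sapiens) for cytotoxicity, read by sulforhodamine B assay, with a stated time of 48 h, tested at 1 uM (a lower number here means a stronger effect, a higher number a weaker effect of the compound at the concentration tested), compound 1 gives 81%. Compound 2 `COc1ccc(-c2cc(/C=C/C(=O)c3ccc(OC)c(OC)c3)[nH]n2)cc1` gives 86%, and compound 3 `COc1cc(-c2cc(/C=C/C(=O)c3ccc(Cl)c(Cl)c3)[nH]n2)cc(OC)c1OC` gives 91%. Within the data shown here, compound 1 has the lowest of the three numbers, but both neighbours sit within the scatter of it: the single-change step a number 10 percentage points higher from compound 1 to compound 3 (within the scatter) is the only measured pair differing in one place, and it lies within the scatter. Compound 2 is not a single-change partner of any measured compound; its number and that of compound 1 are also within the scatter of each other.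

Compound 4 `COc1ccc(-c2cc(/C=C/C(=O)c3ccc(N)cc3)[nH]n2)cc1OC` differs from compound 1 by hydrogen in place of methoxy on an aromatic carbon. Among the measured compounds shown here, no measured step touches the methoxy groups on the aryl attached to the core, so nothing bears directly on this change. For the measured compounds named here, the only measured step, on the carbonyl side, stayed within the scatter, and all three numbers cluster together. The expectation for compound 4 is therefore a step of a number 5 percentage points higher from compound 1 to compound 4 (within the scatter) not beyond the scatter. Compound 4 is estimated at 86%, with a range from 72% to 98%.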

Compound 4, a percentage reported as activity, at one concentration (the size of the read-out at that concentration, not a potency): 87%
Beside the measured number, compound 4's estimate is 1 percentage points below it, within the range that was stated.
By their numbers in this assay, from the lowest: compounds 1, 2, 4 and 3 (each within the scatter of the next).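

In this assay, among these compounds, the change to hydrogen in place of methoxy on an aromatic carbon, ortho to a methoxy group and meta to a large group, appears as a number 6 percentage points higher from compound 1 to compound 4 (within the scatter) and gives the first single-change reading on the aryl attached to the shared core. At this position, the methoxy group of compound 1 can therefore be exchanged for hydrogen without a step beyond the scatter at the one concentration tested, and the same holds on the carbonyl side for a number 10 percentage points higher from compound 1 to compound 3 (within the scatter) in this small set. No supporting measurement accounts for this result.

On these data alone, whether an ethoxy group, a hydroxyl group or a fluorine atom on the same aromatic carbon would stay within the scatter of compound 1 remains open. Also open, as far as these compounds go, is how the aminophenyl series would read with a further methoxy group replaced by hydrogen, leaving a single methoxy group on that aryl.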